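The compounds below may be only part of what the source reports. "The series", "measured", "known", "first", "only" and "open" are said of these compounds alone.

Compound 1 `CC1=CC[C@H](C(C)(C)NC(=S)NN)CC1` and compound 2 `CC1=CC[C@H](C(C)(C)NC(=S)N/N=C/c2ccccc2)CC1` were tested in an ADME assay on Vero cells (Chlorocebus sabaeus) for inhibition, read by sulforhodamine B assay, with a stated time of 48 h; on this read-out higher numbers stand for weaker inhibition of growth and lower numbers for stronger inhibition of growth. For compound 1 the result is a limit of the assay, > 100000 nM. For compound 2 the result is likewise only a limit, > 100000 nM. Compound 2 thus stands at the limit of > 100000 nM in this assay, at which 2 of the 2 values shown sit. Compound 3 `CC1=CC[C@H](C(C)(C)NC(=S)N/N=C/c2ccc(O)cc2)CC1` carries the change (hydroxy in place of hydrogen on an aromatic carbon), hydroxy in place of hydrogen on an aromatic carbon. For the measured compounds named here, no measured step sets a direction for this change. The step from compound 2 to compound 3 in this assay is expected to be a step that the limit leaves unreadable from compound 2 to compound 3, none beyond the scatter. Compound 3 is expected to give about 150000 nM in this assay, with a range from 50000 nM to 500000 nM, quite possibly again reported only as a limit.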

Compound 3, concentration for total growth inhibition: > 100000 nM
Compound 3 was reported as a limit; the forecaster's own chance of this, stated with the estimate: 80%; the middle value is on the limit's open side.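

For the compounds shown here, compound 2 and compound 3 are both reported only as limits, so no step between them can be read. The compounds shown leave open whether hydroxy in place of hydrogen on the aromatic ring changes growth inhibition at all.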